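A few compounds are considered here, and "the series" means these few. Any claim that something is new, unique, unknown or untested is made for them only; others in the source may bear on it.

Three amides on a shared core have been read in a functional assay on KYSE-70 cells for antiproliferative activity against KYSE-70 cell line (Homo sapiens), read by MTT assay, with a stated time of 72 h; a higher number here means a weaker inhibitor, a lower number a stronger inhibitor. Compound 1 `O=C(Nc1ccccn1)c1cc(=O)[nH]c2cc(Br)ccc12` gives 11000 nM and compound 3 `O=C(Nc1cccc(F)c1)c1cc(=O)[nH]c2cc(Br)ccc12` gives 8900 nM, and the change between them is a 1.2-fold lower number from compound 1 to compound 3 (0.09 log units; within the scatter). Compound 2 `O=C(Nc1cc(F)ccc1F)c1cc(=O)[nH]c2cc(Br)ccc12` returns only a limit of the assay, > 20000 nM, and no number. Hydrogen in place of fluoro on an aromatic carbon gives an at least 2.2-fold lower number from compound 2 to compound 3 (0.35 log units; beyond the scatter). Compound 3 therefore stands level with compound 1 and clear of compound 2.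

Compound 4 `O=C(Nc1cccc(OC(F)(F)F)c1)c1cc(=O)[nH]c2cc(Br)ccc12` carries trifluoromethoxy in place of fluoro on an aromatic carbon, meta to a large group: trifluoromethoxy in place of fluoro on an aromatic carbon. Going by the values given here, no measured step makes this exchange, so the evidence is indirect. Among the compounds with values here, the closest guide is the fluoro removal from compound 2, which gives an at least 2.2-fold lower number from compound 2 to compound 3 (0.35 log units; beyond the scatter) and shows only that a change on this ring can shift the number modestly, with its true size hidden behind a limit. The exchange from compound 1, at a 1.2-fold lower number from compound 1 to compound 3 (0.09 log units; within the scatter), moved nothing measurable. In this assay no clear direction is therefore expected, and the expected change is small: a 1.1-fold lower number from compound 3 to compound 4 (0.05 log units; within the scatter). For compound 4 the estimated value is 8000 nM, with an expected range from 3000 nM to 20000 nM.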

Compound 4, half-maximal inhibitory concentration: > 20000 nM
Compound 4: a limit, no number; the forecaster's own chance of this, stated with the estimate: 15%; at least 2.5-fold (0.39 log units) between middle value and limit.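

In this assay compound 4 returns > 20000 nM, which is a limit of the assay and not a number. Trifluoromethoxy in place of fluoro on this aromatic carbon, meta to a large group, gives an at least 2.2-fold higher number from compound 3 to compound 4 (0.35 log units; beyond the scatter), so the group at this very place can move the result beyond the scatter, whereas the earlier step beyond the scatter came from exchanging fluoro for hydrogen and the exchange of the pyridin-2-yl ring for the 3-fluorophenyl ring stayed within it. The true size of this step cannot be read, only its lower bound, and the new result joins an earlier one at the same ceiling: the limit of > 20000 nM in this assay, at which 2 of the 4 values shown sit.

On these data alone, no order can be read between the two compounds that stand at this limit, so it remains unknown whether one is weaker than the other. The compounds shown also leave open how a methoxy group, an amine or a carboxylic acid on this same aromatic carbon would read, and so whether any group other than fluoro can hold the number near that of the 3-fluorophenyl amide.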